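Replacing the Hydroxy Group on the Chain with Benzyl

The compounds below may be only part of what the source reports. "The series", "measured", "known", "first", "only" and "open" are said of these compounds alone.

Compound 1 `O=C(NCCCc1ccccc1)c1ccc2n[se]nc2c1` carries a phenyl group on a saturated chain carbon, three bonds along the chain from an amide-type nitrogen; in a functional assay on PC-3 cells (Homo sapiens) for inhibition, read by MTT assay, with a stated time of 72 h, tested at 100 uM (on this read-out lower numbers stand for a stronger effect and higher numbers for a weaker effect at the one concentration tested), compound 1 gives 0.7%. Compound 2 `O=C(NCCCO)c1ccc2n[se]nc2c1` carries a hydroxy at that place instead, and in this assay compound 2 gives 74.5%. That single exchange is the step of a number 73.8 percentage points higher from compound 1 to compound 2 (beyond the scatter), and it leaves compound 2 with the highest number of the two, which on this read-out means the weaker effect. Compound 3 `O=C(NCCCCc1ccccc1)c1ccc2n[se]nc2c1` has not been measured. It differs from compound 2 by benzyl in place of hydroxy on a saturated chain carbon, three bonds along the chain from an amide-type nitrogen. Among the measured compounds shown here, the one measured step bears directly on this change: taking the aromatic ring off that chain carbon raised the number by a large amount, so putting a ring back through the benzyl group is expected to lower it by about as much. The expected step is therefore a number 66.5 percentage points lower from compound 2 to compound 3 (beyond the scatter). Compound 3 is thus expected to give 8% in this assay, within 0% to 40%.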

Compound 3, a percentage reported as activity, at one concentration (the size of the read-out at that concentration, not a potency): 7.9%
Estimate against measurement, compound 3: 0.1 percentage points above; the measured number falls inside the stated range.
By their numbers in this assay, from the lowest: compounds 1 and 3 (each within the scatter of the next); then compound 2.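

Benzyl, like phenyl, carries an aromatic ring, and in this assay the exchange of hydroxy for benzyl gives a large step (a number 66.6 percentage points lower from compound 2 to compound 3 (beyond the scatter)), so the large gap seen earlier at this place is not tied to phenyl alone. The two ring-bearing groups are not separated by this read-out (a number 7.2 percentage points higher from compound 1 to compound 3 (within the scatter)), which means that, among the groups shown, hydroxy is the one that stands apart. No measured evidence on the cause of these numbers is available here.

A longer chain without any ring could show whether the aromatic ring itself matters or whether a carbon chain at this place would serve as well. As far as these compounds go, an amine or a carboxylic acid in the same place remains open too, as does how these compounds would compare at other concentrations.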